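Series notes: three measured analogues and one pending

The source may hold more compounds than are shown below. What is called first, only, known or untested is meant among the compounds shown, and "the series" means these compounds.

Measured so far:
compound 1, `COc1cccc2cc(-c3ccccc3)c(O)nc12`, 10000 nM
compound 2, `COc1cc(OC)c2cc(-c3ccc(OCc4ccccc4)cc3)c(O)nc2c1`, 10000 nM
compound 3, `CCN(CC)C(=O)Cn1c(=O)c(-c2ccc(OC)cc2)cc2c(OC)cc(OC)cc21`, 10000 nM

In a functional assay on T47D cells (Homo sapiens) for cytotoxicity, read by colorimetric assay and MTT assay (on this read-out higher numbers stand for weaker inhibition and lower numbers for stronger inhibition), compound 1 gives 10000 nM, compound 2 gives 10000 nM and compound 3 gives 10000 nM. Compound 3 stands level with compounds 1 and 2 at the digits shown; its nearest neighbour is compound 1 and its furthest is compound 2, and both gaps lie within the scatter, so no order among the three can be drawn from these numbers. Going by the values given here, no pair of measured compounds differing in a single place is available, so the series itself gives no step from which the effect of a change on the chain at the aromatic nitrogen could be read.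

Compound 4, `COc1ccc(-c2cc3c(OC)cc(OC)cc3n(CCC(=O)OCc3ccccc3)c2=O)cc1`, is the next analogue to be tested in this assay. It differs from compound 3 by (benzyloxycarbonyl)methyl in place of diethylcarbamoyl on a saturated chain carbon bound to an aromatic nitrogen. Compounds 1, 2 and 3 sit at one level across quite different substitution, and the step of no change at the digits printed from compound 3 to compound 4 (within the scatter) is expected to be none beyond the scatter. Compound 4 is accordingly estimated at 10000 nM, with a range from 5000 nM to 20000 nM.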

Compound 4, half-maximal inhibitory concentration: 10000 nM
Estimate against measurement, compound 4: no gap at the digits printed; measured number inside the range.
By their numbers in this assay, from the lowest: compounds 1, 2, 3 and 4 (each within the scatter of the next).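

In this assay, going by these compounds alone, putting (benzyloxycarbonyl)methyl in place of diethylcarbamoyl on a saturated chain carbon bound to an aromatic nitrogen gives no change at the digits printed from compound 3 to compound 4 (within the scatter), the first single-place step. This position therefore accepts a swap from an amide-bearing group to an ester-bearing group carrying a six-membered aromatic ring of carbon only, with the read-out staying within the scatter, which compounds 1, 2 and 3 could not show because no two of them differ in one place alone. No evidence that would explain this flat step is at hand.

Going by these compounds, one step at one position says little about the chain in general, so it remains open whether a carboxylic acid, a primary amine or a longer chain at this place would give a number different from that of compound 3, 10000 nM. Also open, on these data alone, is whether any change elsewhere on the shared core, such as a hydroxyl in place of a methoxy group, would move the read-out in this assay series at all.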